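Moving the Chlorines: From Compound 3 to Compound 4

The source may hold more compounds than are shown below. What is called first, only, known or untested is meant among the compounds shown, and "the series" means these compounds.

In a functional assay on Huh-7 cells (Homo sapiens) for cytotoxicity, read by CCK-8 assay, with a stated time of 72 h (a higher number here means a weaker inhibitor, a lower number a stronger inhibitor), compound 3 `C=CCn1c(=O)/c(=C\c2ccccc2Cl)[nH]c(=O)/c1=C\c1ccccc1OC` gives 6400 nM, the lowest number among the two compounds with a reported value. Compound 2 `C=CCn1c(=O)/c(=C\c2cccc(F)c2)[nH]c(=O)/c1=C\c1ccccc1OC` gives 27200 nM, and compound 1 `COc1ccccc1/C=c1/[nH]c(=O)/c(=C\c2ccccc2OC)n(C)c1=O` is reported as "not active" (no number reported). Going by the values given here, the one measured step, a 4.3-fold lower number from compound 2 to compound 3 (0.63 log units; beyond the scatter), changes the aryl group at the same place as the move to compound 4 `C=CCn1c(=O)/c(=C\c2ccc(Cl)c(Cl)c2)[nH]c(=O)/c1=C\c1ccccc1OC`, where the change is 3,4-dichlorophenyl in place of 2-chlorophenyl on a double-bonded chain carbon bound to an aromatic carbon. That step swapped both the halogen and its ring position, so it only loosely guides the present change, which again alters the chlorine pattern on that ring. Compound 4 is therefore expected to stay close to compound 3, with the step of a 1.3-fold higher number from compound 3 to compound 4 (0.10 log units; within the scatter) and either direction possible. In this assay compound 4 is estimated at 8000 nM, within 2500 nM to 30000 nM.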

Compound 4, half-maximal inhibitory concentration: "not active" (no number reported)
Compound 4: no number reported, and the estimate cannot be compared.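

In this assay, going by these compounds alone, compound 4 stands as "not active" (no number reported), so no step from compound 3 to compound 4 can be read. From the compounds shown here alone, how 3,4-dichlorophenyl compares with 2-chlorophenyl in size of effect stays open. No measured evidence bears on this result.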